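A Shorter Chain Coming Back From the Limit

This account rests on a few compounds, and the source may have more. Where it says the series, first, only, none or still open, it means among the compounds named here.

In a functional assay on MDA-MB-231 cells (Homo sapiens) for inhibition, read by MTT assay, with a stated time of 72 h (a higher number here means a weaker inhibitor, a lower number a stronger inhibitor), compound 2 (`Nc1nc2cc(-c3nn(CCCCCCCCCC(=O)NO)c4ncnc(N)c34)ccc2o1`) stands at > 50000 nM as a limit of the assay and not a number. Compound 1 (`Nc1nc2cc(-c3nn(CCCC(=O)NO)c4ncnc(N)c34)ccc2o1`) reads 19500 nM as a measured number in this assay and gives the only firm footing nearby. Among the measured compounds shown here, the one measured step that bears on the change ahead is an at least 2.5-fold higher number from compound 1 to compound 2 (0.40 log units; beyond the scatter) with the longer chain on the higher side; it lies beyond the scatter, though one end of it is a limit. Compound 3 (`Nc1nc2cc(-c3nn(CCC(=O)NO)c4ncnc(N)c34)ccc2o1`) differs from compound 2 by hydroxycarbamoyl in place of 7-(hydroxycarbamoyl)heptyl on a saturated chain carbon, two bonds along the chain from an aromatic nitrogen in one place: hydroxycarbamoyl in place of 7-(hydroxycarbamoyl)heptyl on a saturated chain carbon, two bonds along the chain from an aromatic nitrogen. Read backward, an at least 2.5-fold higher number from compound 1 to compound 2 (0.40 log units; beyond the scatter) points to a lower number for compound 3 with its shorter chain. The step expected is an at least 2.0-fold lower number from compound 2 to compound 3 (0.30 log units; that floor lies within the scatter) in size. In this assay the estimate for compound 3 is 25000 nM with an expected range from 10000 nM to 50000 nM as its upper end.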

Compound 3, half-maximal inhibitory concentration: > 50000 nM
Compound 3 was reported as a limit (the forecaster's own chance of this, stated with the estimate: 20%); middle value at least 2.0-fold (0.30 log units) away from the limit.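

In this assay, the shortening that lowered the number from compound 2 to compound 1 does not continue, for the change to hydroxycarbamoyl in place of (hydroxycarbamoyl)methyl gives an at least 2.5-fold higher number from compound 1 to compound 3 (0.40 log units; beyond the scatter), so compound 1 now stands lower than the compounds on either side of it in chain length. Compound 3 gives > 50000 nM, a limit of the assay and not a number. The step between compound 2 and compound 3 cannot be read, because both compounds sit at the same limit: the limit of > 50000 nM in this assay, at which 2 of the 3 values shown sit.

The compounds shown leave open how a chain of a length between those of compound 1 and compound 2 would read. They also leave open whether a carboxylic acid or an amine in place of the hydroxycarbamoyl on the chain of compound 1 would keep its measured number.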